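Swapping an Aryl Amine for a Benzyl Amine

The compounds below may be only part of what the source reports. "The series", "measured", "known", "first", "only" and "open" are said of these compounds alone.

Compound 1, `Cc1ccc(Nc2nc(N)nc(COc3ccc4c(C)cc(=O)oc4c3)n2)cc1Cl`: 140 nM
Compound 2, `Cc1cc(=O)oc2cc(OCc3nc(N)nc(Nc4ccc(Cl)c(Cl)c4)n3)ccc12`: 780 nM
Compound 3, `Cc1ccc(Nc2nc(N)nc(COc3ccc4c(C)cc(=O)oc4c3)n2)cc1C`: 210 nM

These three compounds share one core and differ only in the ring carried on the amine nitrogen. The numbers come from an assay on COS-7 cells for agonist activity at Free fatty acid receptor 1 (Homo sapiens), read by scintillation counting and inositol phosphate accumulation, with a stated time of 90 min; a lower number here means that less compound is needed, a higher number that more compound is needed for the effect. Compound 3 stands second highest of the three: the step of a 1.5-fold higher number from compound 1 to compound 3 (0.18 log units; within the scatter) lies within the scatter, so compound 1 and compound 3 cannot be told apart, whereas the step of a 3.7-fold lower number from compound 2 to compound 3 (0.57 log units; beyond the scatter) lies beyond it.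

Compound 4, `Cc1cc(=O)oc2cc(OCc3nc(N)nc(NCc4ccc(F)cc4)n3)ccc12`, has not yet been measured. It differs from compound 3 in one place: 4-fluorobenzyl in place of 3,4-dimethylphenyl on a nitrogen on an aromatic ring. The measured steps all concern swaps between chloro and methyl on that same ring. Of these, a 5.6-fold higher number from compound 1 to compound 2 (0.75 log units; beyond the scatter) and a 3.7-fold lower number from compound 2 to compound 3 (0.57 log units; beyond the scatter) are modest, and a 1.5-fold higher number from compound 1 to compound 3 (0.18 log units; within the scatter) is within the scatter. None of them inserts a carbon between the nitrogen and the ring, and none brings in fluorine, so they bear only loosely on this change. Going by the values given here, with no direct precedent, the step of a 2.9-fold higher number from compound 3 to compound 4 (0.46 log units; beyond the scatter) is the expectation, leaning towards a somewhat higher number. Compound 4 is estimated at 600 nM, with a range from 150 nM to 3000 nM.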

Compound 4, half-maximal effective concentration: 7820 nM
Estimate against measurement, compound 4: 13-fold (1.12 log units) below, outside the stated range (above it).
By their numbers in this assay, from the lowest: compounds 1 and 3 (each within the scatter of the next); then compound 2; then compound 4.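

In this assay, swaps between chloro and methyl on the aromatic ring gave steps no larger than a 5.6-fold higher number from compound 1 to compound 2 (0.75 log units; beyond the scatter), whereas replacing the whole ring group with 4-fluorobenzyl gives a 37-fold higher number from compound 3 to compound 4 (1.57 log units; beyond the scatter), along with a 56-fold higher number from compound 1 to compound 4 (1.75 log units; beyond the scatter) and a 10-fold higher number from compound 2 to compound 4 (1.00 log units; beyond the scatter). All three new steps are beyond the scatter and point the same way, so this position on the nitrogen accepts chloro and methyl changes on the aromatic ring far better than the change from (3,4-dimethylphenyl)amino to (4-fluorobenzyl)amino. No measurement shown here accounts for the size of this rise.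

The change to compound 4 alters several things at once: it adds a carbon between the nitrogen and the ring, brings in fluorine and removes the earlier chloro and methyl groups, and the compounds shown cannot separate these contributions. From the compounds shown here alone, a fluorophenyl group on the same nitrogen would test the fluorine without the added carbon, while a 3,4-dimethylbenzyl or 3,4-dichlorobenzyl group would test the added carbon with the earlier ring substituents kept, and both remain open here.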